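The source may report more compounds than this note shows. Statements on the series, on what has been measured and on what is new or still open speak of the compounds shown alone.

Measured compounds: compound 1 `Cn1cc(-c2cccc3c2CCC3c2ncc[nH]2)cn1` with > 10000 nM in a functional assay on CHO cells for agonist activity at Alpha-1D adrenergic receptor (Homo sapiens), read by FLIPR and calcium flux; on this read-out lower numbers stand for an effect already at smaller amounts and higher numbers for an effect only at larger amounts of compound; compound 2 `Cc1n[nH]cc1-c1cccc2c1CCC2c1ncc[nH]1` with 634 nM; compound 3 `c1cc(-c2ccn[nH]2)c2c(c1)C(c1ncc[nH]1)CC2` with 336 nM. The value of compound 1 is a limit of this assay, not a number (the limit of > 10000 nM in this assay, at which 1 of the 3 values shown sits).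

Compound 3 gives the lowest number shown, though compound 2 sits within the scatter of it a 1.9-fold lower number from compound 2 to compound 3 (0.28 log units; within the scatter). Compound 4 `c1cc(-c2ncco2)c2c(c1)C(c1ncc[nH]1)CC2` differs from compound 3 in one place: 1,3-oxazol-2-yl in place of 1H-pyrazol-5-yl on an aromatic carbon. The two steps that bear on this change of the five-membered ring, an at least 15-fold lower number from compound 1 to compound 2 (1.19 log units; beyond the scatter) and an at least 29-fold lower number from compound 1 to compound 3 (1.47 log units; beyond the scatter), were both large. A large step is therefore expected here too, toward higher numbers, a 15-fold higher number from compound 3 to compound 4 (1.17 log units; beyond the scatter). Compound 4 is estimated at 5000 nM, within 1000 nM to 25000 nM.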

Compound 4, half-maximal effective concentration: 1390 nM
Compound 4: the middle estimate sits 3.6-fold (0.56 log units) above what was measured; measured number inside the range.
By their numbers in this assay, from the lowest: compounds 3 and 2 (each within the scatter of the next); then compound 4. At a limit, above all of these: compound 1.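

In this assay, a 1,3-oxazol-2-yl ring with 0 hydrogen-bond donors on this aromatic carbon still gives a measured number, at some cost against both pyrazoles (a 4.1-fold higher number from compound 3 to compound 4 (0.62 log units; beyond the scatter)) and (a 2.2-fold higher number from compound 2 to compound 4 (0.34 log units; beyond the scatter)). It also stays clear of the 1-methyl-1H-pyrazol-4-yl ring (an at least 7.1-fold lower number from compound 1 to compound 4 (0.85 log units; beyond the scatter)). That last step rests on a value of compound 1 that is a limit, not a number: the limit of > 10000 nM in this assay, at which 1 of the 4 values shown sits.

The compounds shown leave open how an amine or a carboxylic acid on this five-membered ring would read. They also leave open how a six-membered pyridine ring at this place would read.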